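From chloro to fluoro at an assay limit

The compounds below may be only part of what the source reports. "The series", "measured", "known", "first", "only" and "open" are said of these compounds alone.

Compound 1 (`CNC(=O)c1cc(Oc2ccc(NC(=O)c3cc(-c4ccc(Cl)cc4)ncn3)cc2F)ccn1`) gives > 100000 nM as a limit
Compound 2 (`CNC(=O)c1cc(Oc2ccc(NC(=O)c3cc(-c4ccc(Cl)cc4)ncn3)cc2)ccn1`) gives > 100000 nM as a limit

Both readings come from a functional assay on MCF7 cells (Homo sapiens) for cytotoxicity, read by MTT assay, with a stated time of 72 h (on this read-out lower numbers stand for stronger inhibition and higher numbers for weaker inhibition), and neither is a number. Compound 2 therefore stands only at a limit, so its true potency cannot be read. The whole picture so far is short (the limit of > 100000 nM in this assay, at which 2 of the 2 values shown sit) and gives no graded scale to work from.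

Compound 3 (`CNC(=O)c1cc(Oc2ccc(NC(=O)c3cc(-c4ccc(F)cc4)ncn3)cc2)ccn1`) changes one place of compound 2 (fluoro in place of chloro on an aromatic carbon) with fluoro in place of chloro on an aromatic carbon, so 4-chlorophenyl becomes 4-fluorophenyl.

Going by the values given here, the one measured step (a step that the two limits leave unreadable from compound 1 to compound 2) has hydrogen in place of fluoro on an aromatic carbon, and it gives no size to carry over. Among the compounds with values here, no measured step exchanges chloro for fluoro. No step beyond the usual scatter is therefore expected in this assay for this change. This expectation starts from compound 2 and its limit (> 100000 nM) alone. The expected change (a number no higher from compound 2 to compound 3 (the limit leaves the size open)) is small. Compound 3 is estimated at 100000 nM with an expected range from 30000 nM to 300000 nM and is expected to be reported most likely as a limit again.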

Compound 3, half-maximal inhibitory concentration: > 100000 nM
Compound 3: a limit, no number; the forecaster's own chance of this, stated with the estimate: 80%; the middle value sits exactly at the limit.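

In this assay compound 3 gives > 100000 nM, which is a limit and not a number. Compound 2 and compound 3 therefore stand only at limits, so no size can be read for the step between them. The compounds shown leave open how they truly rank and what fluoro in place of chloro does to potency, with every reading at one limit: the limit of > 100000 nM in this assay, at which 3 of the 3 values shown sit.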